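This account rests on a few compounds, and the source may have more. Where it says the series, first, only, none or still open, it means among the compounds named here.

Measured in a functional assay on L1210 cells (Mus musculus) for inhibition, with a stated time of 48 h; a lower number here means a stronger inhibitor, a higher number a weaker inhibitor:
Compound 1 `COC(=O)C[C@H](NC(=O)OC(C)(C)C)C(=O)N(Cc1ccccc1)C1(C(=O)NCc2ccccc2)CCN(Cc2ccccc2)CC1`: 18000 nM
Compound 2 `COC(=O)C[C@H](NC(=O)OC(C)(C)C)C(=O)N(Cc1ccccc1)C1(C(=O)NCc2ccccc2)CCNCC1`: > 200000 nM, a limit of the assay and not a number
Compound 3 `CCC(C)N(C(=O)[C@@H](N)CC(=O)OC)C1(C(=O)NCc2ccccc2)CCN(Cc2ccccc2)CC1`: 244000 nM

Compound 1 and compound 2 differ in one place only, (hydrogen in place of benzyl on an amine nitrogen in a ring), and in this assay this gave an at least 11-fold higher number from compound 1 to compound 2 (1.04 log units; beyond the scatter). Compound 3 shares this pair's core in broad outline, but how the core of compound 3 differs from that of compound 1 is not broken down here; among the two numbers in this assay compound 3 stands highest, with compound 1 the nearest.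

Compound 4 `CCC(C)N(C(=O)[C@@H](N)CC(=O)OC)C1(C(=O)NCc2ccccc2)CCNCC1` is not yet measured. It arises from compound 3 by the same change, (hydrogen in place of benzyl on an amine nitrogen in a ring), at the same place in the ring. Since compound 2 already sits at the limit of > 200000 nM in this assay, at which 1 of the 3 values shown sits, and compound 3 starts from a higher number than compound 1, a step of a 4.1-fold higher number from compound 3 to compound 4 (0.61 log units; beyond the scatter) is expected, with the real chance that only a limit is reported. Compound 4 is therefore estimated at 1000000 nM, between 250000 nM and 5000000 nM.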

Compound 4, half-maximal inhibitory concentration: > 250000 nM
Compound 4: only a limit was reported; the forecaster's own chance of this, stated with the estimate: 80%; the middle value does not contradict the limit.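

In this assay compound 4 gives > 250000 nM, which is a limit of the assay and not a number. Hydrogen in place of benzyl on the amine nitrogen in the ring gives an at least 1.0-fold higher number from compound 3 to compound 4 (0.01 log units; that floor lies within the scatter), a result that is compatible with the change carrying over to the core of compound 3 but does not establish a rise in the number on that core, and gives no size for the step there. Whether the change acts to the same extent on both cores therefore stays unsettled: the same change on two cores in this assay, an at least 11-fold higher number (1.04 log units; beyond the scatter) from compound 1 to compound 2 and an at least 1.0-fold higher number (0.01 log units; that floor lies within the scatter) from compound 3 to compound 4; the limit leaves it open whether they differ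

The compounds shown leave open how other groups on that ring nitrogen would read in this assay, for instance a methyl, an acetyl or a longer chain such as phenylethyl in place of benzyl. They also leave open whether a carboxylic acid in place of the methyl ester would alter what the change does on either core.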